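Added ring fluoro next in the acid series: compound 3

The source may hold more compounds than are shown below. What is called first, only, known or untested is meant among the compounds shown, and "the series" means these compounds.

Measured so far in a functional assay on HEK293 cells for agonist activity at Free fatty acid receptor 1 (Homo sapiens), read by HTRF and inositol phosphate accumulation, with a stated time of 60 min; a lower number here means that less compound is needed, a higher number that more compound is needed for the effect:
compound 1 `O=C(O)CC[C@H]1CCc2cc(-c3cc(OC4CCC4)ccc3F)ccc2O1`: 3600 nM
compound 2 `O=C(O)CC[C@H]1CCc2cc(-c3cc(OC(F)(F)F)ccc3F)ccc2O1`: 2100 nM

Compound 1 holds the larger of the two numbers shown, although the step of a 1.7-fold lower number from compound 1 to compound 2 (0.23 log units; within the scatter) remains within the scatter, so neither compound can be called the more potent. Compound 3 `O=C(O)CC[C@H]1CCc2cc(-c3cc(OC4CCC4)cc(F)c3F)ccc2O1` differs from compound 1 by fluoro in place of hydrogen on an aromatic carbon. Among the compounds with values here, the one measured step, a 1.7-fold lower number from compound 1 to compound 2 (0.23 log units; within the scatter), alters the group on the oxygen and says nothing about a fluoro added to the ring; no step informs this change. The step of a 1.1-fold lower number from compound 1 to compound 3 (0.02 log units; within the scatter) is therefore expected to stay within the scatter. For compound 3 the estimate in this assay is 3400 nM, with a range from 1200 nM to 9500 nM.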

Compound 3, half-maximal effective concentration: > 10000 nM
Compound 3 was reported as a limit; the forecaster's own chance of this, stated with the estimate: 5%; middle value at least 2.9-fold (0.46 log units) away from the limit.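

Fluoro in place of hydrogen on this aromatic carbon, ortho to a fluoro group and meta to a cyclobutyloxy group, gives an at least 2.7-fold higher number from compound 1 to compound 3 (0.44 log units; beyond the scatter), so the position is sensitive to this change. The only other step shown, a 1.7-fold lower number from compound 1 to compound 2 (0.23 log units; within the scatter), alters the group on the oxygen rather than the ring. The reading for compound 3 is a limit, not a number: the limit of > 10000 nM in this assay, at which 1 of the 3 values shown sits.

As far as these compounds go, whether a chloro or a methyl on this carbon would give the same result remains open. Also open, from the compounds shown here alone, is whether the added fluoro would have the same effect on compound 2, with trifluoromethyl on the oxygen.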